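Fluorine on the Sugar Ring: Expected Effect on Cytotoxicity

The source may hold more compounds than are shown below. What is called first, only, known or untested is meant among the compounds shown, and "the series" means these compounds.

Compound 3 `O=c1nc(NO)ccn1[C@@H]1CC[C@H](CO)O1` was tested in an ADME assay on HL-60 cells (Homo sapiens) for cytotoxicity, read by MTT assay, with a stated time of 3 days (on this read-out lower numbers stand for higher toxicity in this test and higher numbers for lower toxicity in this test), where it gives 1600000 nM. Among the three measured compounds this is the second highest number, but the spread is small: compound 1 `O=c1nc(NO)c(F)cn1[C@@H]1C[C@@H](O)[C@H](CO)O1` gives 1370000 nM and compound 2 `[N-]=[N+]=N[C@@H]1C[C@@H](n2ccc(NO)nc2=O)O[C@H]1CO` gives 2000000 nM, and each of these sits within the scatter of compound 3. Among the measured compounds shown here, the only step between measured compounds that differ in one place is a 1.3-fold lower number from compound 2 to compound 3 (0.10 log units; within the scatter), a change on the saturated ring. Compound 4 `O=c1nc(NO)ccn1[C@@H]1CC(F)[C@H](CO)O1` differs from compound 3 by fluoro in place of hydrogen on a saturated ring carbon. For the measured compounds named here, no measured pair shows a hydrogen replaced by fluoro on a saturated ring carbon; the nearest guide is the azido-to-hydrogen step on that ring, which stayed within the scatter, and all three measured numbers lie close together. The expectation for compound 4 is therefore a step of a 1.1-fold lower number from compound 3 to compound 4 (0.03 log units; within the scatter), not beyond the scatter. Compound 4 is estimated at 1500000 nM, with a range from 700000 nM to 3200000 nM.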

Compound 4, half-maximal cytotoxic concentration: 4400000 nM
The estimate for compound 4 lay 2.9-fold (0.47 log units) below the measured number, and the stated range ends below it.
By their numbers in this assay, from the lowest: compounds 1, 3 and 2 (each within the scatter of the next); then compound 4.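

In this assay the change gives a 2.8-fold higher number from compound 3 to compound 4 (0.44 log units; beyond the scatter) and thus moves the number beyond the scatter, towards lower toxicity in this test. The earlier change on this ring carbon, a 1.3-fold lower number from compound 2 to compound 3 (0.10 log units; within the scatter), stayed within the scatter, and this new step is the first sign among these compounds that the group on this carbon can shift the number. Nothing shown here explains why a single fluoro has this effect.

As far as these compounds go, whether an amine or a methoxy group on this ring carbon would shift the number in the same way remains open. This is also the only pair shown with fluoro in place of hydrogen on a saturated ring carbon, and whether the step would recur on another core remains unknown.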